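A few compounds are considered here, and "the series" means these few. Any claim that something is new, unique, unknown or untested is made for them only; others in the source may bear on it.

For the measured compounds named here, in a functional assay on A549 cells (Homo sapiens) for antiproliferative activity, read by MTT assay, with a stated time of 72 h (on this read-out higher numbers stand for weaker inhibition and lower numbers for stronger inhibition), compound 3 (`NC1=NC2(CCSCC2)N(OCCCOc2cccc(Cl)c2Cl)C(N)=N1`) gives 1 nM, the lowest number so far. Compound 1 (`NC1=NC2(CCOCC2)N(OCCCOc2cccc(Cl)c2Cl)C(N)=N1`) gives 100 nM, and compound 2 (`NC1=NC2(CCOCC2)N(OCCCOc2ccccc2Cl)C(N)=N1`) gives 2700 nM. Compound 4 (`COc1ccc(OCCCON2C(N)=NC(N)=NC23CCSCC3)cc1`) keeps the shared core of compound 3 but changes the aromatic group on the chain: 4-methoxyphenyl in place of 2,3-dichlorophenyl on an oxygen on a saturated carbon. The measured step that bears on this is a 27-fold higher number from compound 1 to compound 2 (1.43 log units; beyond the scatter), a large change beyond the scatter in which hydrogen takes the place of chloro on an aromatic carbon. The change to compound 4 removes the whole 2,3-dichlorophenyl group, so a similar loss is a reasonable expectation. Going by the values given here, no measured compound carries 4-methoxyphenyl, however, which leaves the size of the step less certain than its direction. In this assay the expected step is a 100-fold higher number from compound 3 to compound 4 (2.00 log units; beyond the scatter), a large move towards weaker inhibition. For compound 4 the estimated value is 100 nM, with an expected range from 10 nM to 1500 nM.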

Compound 4, half-maximal inhibitory concentration: 240 nM
Estimate against measurement, compound 4: 2.4-fold (0.38 log units) below, and the stated range covers the measured number.
By their numbers in this assay, from the lowest: compound 3; then compound 1; then compound 4; then compound 2.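

In this assay, the swap on the oxygen at the end of the chain gives a 240-fold higher number from compound 3 to compound 4 (2.38 log units; beyond the scatter), so this position responds strongly on the core of compound 3 as well, and to replacing the whole aromatic group, not only to losing one chloro. The two groups match in what can be counted: each has 8 heavy atoms and one six-membered aromatic ring of carbon only, so those counts alone do not predict the result. The entering 4-methoxyphenyl differs by carrying one hydrogen-bond acceptor, but nothing available explains why activity falls so far.

Still open, as far as these compounds go, is whether the step comes from losing the two chloro groups or from gaining the methoxy group, as both happen at once. Plain phenyl or 4-chlorophenyl on the core of compound 3 would help separate these two contributions.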